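Swapping a Thiadiazole for an Oxadiazole on a Shared Core

This account rests on a few compounds, and the source may have more. Where it says the series, first, only, none or still open, it means among the compounds named here.

Of the compounds shown here, two have been tested in a functional assay on LM7 cells (Homo sapiens) for cytotoxicity, read by MTT assay, with a stated time of 72 h (on this read-out lower numbers stand for stronger inhibition and higher numbers for weaker inhibition), so far. Compound 1 `Cc1nnc(SCc2cc(=O)c3ccccc3o2)o1` gives only a limit, > 25000 nM, and no number. Compound 2 `Cc1ccc2oc(CSc3nnc(C)s3)cc(=O)c2c1` likewise gives only a limit, > 25000 nM. For the measured compounds named here, compound 2 therefore stands nowhere in particular on a scale: its value is the boundary of what this assay reports, and the same is true of the one other value shown, as summed up by the limit of > 25000 nM in this assay, at which 2 of the 2 values shown sit. Because both values are limits, nothing can be said about order or change between compound 1 and compound 2.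

Compound 3 `Cc1ccc2oc(CSc3nnc(C)o3)cc(=O)c2c1` is not yet measured. It differs from compound 2 in one place: 5-methyl-1,3,4-oxadiazol-2-yl in place of 5-methyl-1,3,4-thiadiazol-2-yl on a sulfur. Going by the values given here, no measured pair isolates this change, so there is no step to lean on. Given that compound 2 reaches only a limit in this assay, the expectation is that the step from compound 2 to compound 3 is none beyond the scatter, a number no higher from compound 2 to compound 3 (the limit leaves the size open). Compound 3 is thus expected to sit at about 25000 nM, within a range from 10000 nM to 60000 nM, most likely again reported only as a limit.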

Compound 3, half-maximal inhibitory concentration: > 25000 nM
Compound 3: no number, only a limit (the forecaster's own chance of this, stated with the estimate: 85%); the middle value lies on the limit itself.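

No step can be read from compound 2 to compound 3 or from compound 1 to compound 3, because each of these compounds gives only a limit and no number: the limit of > 25000 nM in this assay, at which 3 of the 3 values shown sit.

The compounds shown leave open whether 5-methyl-1,3,4-oxadiazol-2-yl in place of 5-methyl-1,3,4-thiadiazol-2-yl, or methyl in place of hydrogen, changes the result at all.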